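Changing the ester chain on the nitrogen of compound 2

This account rests on a few compounds, and the source may have more. Where it says the series, first, only, none or still open, it means among the compounds named here.

- compound 1 `COc1cc(OC)c(/C=C/S(=O)(=O)Cc2ccc(OC)c(N)c2)c(OC)c1` gives 2.5 nM
- compound 2 `COC(=O)CCNc1cc(CS(=O)(=O)/C=C/c2c(OC)cc(OC)cc2OC)ccc1OC` gives 1000 nM

Both values come from a functional assay on K562 cells (Homo sapiens) for cytotoxicity, read by trypan blue exclusion, with a stated time of 96 h; a lower number here means a stronger inhibitor, a higher number a weaker inhibitor. Compound 2 stands at the high end of these two numbers, which makes it the weaker inhibitor. Among the compounds with values here, the one measured step is a 400-fold higher number from compound 1 to compound 2 (2.60 log units; beyond the scatter). It goes with 2-(methoxycarbonyl)ethyl in place of hydrogen on a nitrogen on an aromatic ring.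

Within the data shown here, compound 3 `COC(=O)C(F)(F)Nc1cc(CS(=O)(=O)/C=C/c2c(OC)cc(OC)cc2OC)ccc1OC` keeps the core of compound 2 and changes only that group: difluoro(methoxycarbonyl)methyl in place of 2-(methoxycarbonyl)ethyl on a nitrogen on an aromatic ring. In words, difluoro(methoxycarbonyl)methyl comes in place of 2-(methoxycarbonyl)ethyl on the same nitrogen. Among the measured compounds shown here, no measured pair tests this swap directly. The step to compound 2 from compound 1 concerns the same nitrogen, yet compound 3 still carries a group there and does not return to hydrogen. A return to a value near that of compound 1, at 2.5 nM, is therefore not expected. In this assay, a small shift with a slight lean to a lower number is expected, and the data leave wide uncertainty. The estimated change is a 2.0-fold lower number from compound 2 to compound 3 (0.30 log units; within the scatter). For compound 3 the expected value is 500 nM, within an estimated range of 60 nM to 3000 nM.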

Compound 3, half-maximal inhibitory concentration: 250 nM
For compound 3 the middle estimate is 2.0-fold (0.30 log units) above the measured one; the range from low to high includes it.
By their numbers in this assay, from the lowest: compound 1; then compound 3; then compound 2.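

In this assay the swap of 2-(methoxycarbonyl)ethyl for difluoro(methoxycarbonyl)methyl gives a 4.0-fold lower number from compound 2 to compound 3 (0.60 log units; beyond the scatter) and so shows that the identity of the ester chain on this nitrogen matters, not only whether a chain is present. The gain is small beside the cost of placing this chain on the nitrogen, as replacing hydrogen with difluoro(methoxycarbonyl)methyl still gives a 100-fold higher number from compound 1 to compound 3 (2.00 log units; beyond the scatter) and compound 1 remains well ahead of both chain-bearing compounds. No available evidence explains the difference between the two chains.

Both chains end in a methyl ester, so a carboxylic acid in that place, or a plain methyl group on the nitrogen, would help separate the part played by the ester from the part played by having any group there at all. The swap also changes the fluorine and carbon content of the chain together, and methoxycarbonylmethyl, the same chain without fluorine, would show how much of this modest step goes with the fluorine atoms.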